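The source may hold more compounds than are shown below. What is called first, only, known or untested is meant among the compounds shown, and "the series" means these compounds.

The three compounds measured in a functional assay on the whole organism (strain Wistar) for inhibition, with Rattus norvegicus as the target, read by paw edema, with stated times of 30 min and 5 h, at a dose of 0.05 mmol/kg by the oral route (a higher number here means more inhibition at the dose given (going by the name of the read-out), a lower number less inhibition), share one core and differ only in the aryl group on the carbon with a double bond to nitrogen. Compound 1 `Cc1cc(C2=NN(c3ccc(S(C)(=O)=O)cc3)C(=O)CC2)ccc1O` gives 60.5%, compound 2 `Cc1cc(O)ccc1C1=NN(c2ccc(S(C)(=O)=O)cc2)C(=O)CC1` gives 52.6%, and compound 3 `CC(C)(C)c1ccc(C2=NN(c3ccc(S(C)(=O)=O)cc3)C(=O)CC2)cc1` gives 68.4%. Compound 2 lies under compound 3 by a margin beyond the scatter, whereas its gap to compound 1 stays within it: the step of a number 7.9 percentage points lower from compound 1 to compound 2 (within the scatter), with 4-hydroxy-2-methylphenyl in place of 4-hydroxy-3-methylphenyl, left the read-out essentially unchanged.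

Compound 4 `CS(=O)(=O)c1ccc(N2N=C(c3ccc(O)c(Cl)c3)CCC2=O)cc1` has not yet been measured. It arises from compound 2 by 3-chloro-4-hydroxyphenyl in place of 4-hydroxy-2-methylphenyl on a carbon with a double bond to nitrogen. Among the compounds with values here, the one measured step that bears on this change is the one from compound 1 to compound 2, which stayed within the scatter. The 3-chloro-4-hydroxyphenyl of compound 4 resembles the 4-hydroxy-3-methylphenyl of compound 1 more than the 4-hydroxy-2-methylphenyl of compound 2, so the reading of compound 1 is taken as the nearer guide. Compound 4 is therefore expected to come out close to compound 1, and the estimated step of a number 7.4 percentage points higher from compound 2 to compound 4 (within the scatter) is expected to remain within the scatter. The estimate for compound 4 in this assay is 60%, with a range from 45% to 75%.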

Compound 4, a percentage reported as inhibition, in the whole organism at one dose (the size of the read-out at that dose, not a potency): 55.2%
Estimate against measurement, compound 4: 4.8 percentage points above; the measured number falls inside the stated range.
By their numbers in this assay, from the lowest: compounds 2, 4, 1 and 3 (each within the scatter of the next, the first and the last beyond it).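

In this assay, within the data shown here, the step of a number 5.3 percentage points lower from compound 1 to compound 4 (within the scatter) with chloro in place of methyl on an aromatic carbon gives the first direct comparison of two groups at this position, and the inhibition of paw edema at this dose does not separate them. The step of a number 2.6 percentage points higher from compound 2 to compound 4 (within the scatter) with 3-chloro-4-hydroxyphenyl in place of 4-hydroxy-2-methylphenyl also stays within the scatter, so exchanging the methyl-bearing aryl group of compound 2 for the chloro-bearing one of compound 4 produces no difference that this assay can resolve. Nothing measured here offers an explanation for these readings.

On these data alone, it remains open whether a methoxy group, an amine or a longer chain such as propyl in the place of the chloro of compound 4 would give a reading beyond the scatter, and whether a carboxylic acid in place of the hydroxy group would do so. A reading at a single dose also leaves open how compound 1, compound 2 and compound 4 would compare at other doses.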